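Sulfonamide in place of hydroxyalkyl on the side chain

The source may report more compounds than this note shows. Statements on the series, on what has been measured and on what is new or still open speak of the compounds shown alone.

Measured compounds:
compound 1 `CC(C)(C)OC(=O)NCCCNC(=O)CN1CN(c2ccccc2)C2(CCN(C(=O)c3ccc(C(C)(C)C)cc3)CC2)C1=O` gives 4500 nM in an assay on HEK293 cells for displacement of a labelled ligand from NPC1-like intracellular cholesterol transporter 1 (Homo sapiens); a higher number here means a weaker inhibitor, a lower number a stronger inhibitor;
compound 2 `CC(C)(C)c1ccc(C(=O)N2CCC3(CC2)C(=O)N(CC(=O)NCCCCO)CN3c2ccccc2)cc1` gives 19200 nM;
compound 3 `CC(C)(C)c1ccc(C(=O)N2CCC3(CC2)C(=O)N(CC(=O)NCCCCCO)CN3c2ccccc2)cc1` gives 9400 nM.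

Compound 3 stands second highest of the three numbers in this assay: compound 2 sits above it (a 2.0-fold lower number from compound 2 to compound 3 (0.31 log units; beyond the scatter)) and compound 1 below it (a 2.1-fold higher number from compound 1 to compound 3 (0.32 log units; beyond the scatter)). The unmeasured compound 4 `CC(C)(C)c1ccc(C(=O)N2CCC3(CC2)C(=O)N(CC(=O)NCCCNS(C)(=O)=O)CN3c2ccccc2)cc1` differs from compound 3 by methanesulfonamido in place of 2-hydroxyethyl on a saturated chain carbon, three bonds along the chain from an amide-type nitrogen. Among the compounds with values here, the step that bears on this change is the one from a nitrogen-bearing group to the hydroxyalkyl chain at the same place, a 2.1-fold higher number from compound 1 to compound 3 (0.32 log units; beyond the scatter), which was modest. Returning a nitrogen-bearing group is therefore expected to give a modest step back toward the number of compound 1, a 1.7-fold lower number from compound 3 to compound 4 (0.23 log units; within the scatter). Compound 4 is estimated at 5500 nM, with a range from 2000 nM to 15000 nM.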

Compound 4, half-maximal inhibitory concentration: 10400 nM
Compound 4: middle estimate off by 1.9-fold (0.28 log units), on the low side, and the stated range covers the measured number.
By their numbers in this assay, from the lowest: compound 1; then compounds 3, 4 and 2 (each within the scatter of the next, the first and the last beyond it).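

In this assay the methanesulfonamido chain of compound 4 cannot be told apart from the hydroxyalkyl chains: a 1.1-fold higher number from compound 3 to compound 4 (0.04 log units; within the scatter) and a 1.8-fold lower number from compound 2 to compound 4 (0.27 log units; within the scatter) both lie within the scatter. A nitrogen on the chain is therefore not enough to reach the number of compound 1, as methylsulfonyl in place of tert-butoxycarbonyl on an amine nitrogen gives a 2.3-fold higher number from compound 1 to compound 4 (0.36 log units; beyond the scatter) and this step lies beyond the scatter. Nothing available explains these steps.

Still open, from the compounds shown here alone, is whether a free amine or a carboxylic acid at this place would fall nearer compound 1 or compound 4. Also open, going by these compounds, is whether a longer chain carrying methanesulfonamido would change the number.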